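A few compounds are considered here, and "the series" means these few. Any claim that something is new, unique, unknown or untested is made for them only; others in the source may bear on it.

Compound 1 `C#CCCOC(=O)c1ccc(C(CC)(CC)c2ccc(OCCC(O)(CC)CC)c(C)c2)n1CC`: > 50000 nM
Compound 2 `CCC(C)C(NC(=O)c1ccc(C(CC)(CC)c2ccc(OCCC(O)(CC)CC)c(C)c2)n1CC)C(=O)OC`: > 50000 nM

In a functional assay on Caco-2 cells (Homo sapiens) for antiproliferative activity, read by MTT assay, with a stated time of 48 h (on this read-out lower numbers stand for stronger inhibition and higher numbers for weaker inhibition), compound 2 gives > 50000 nM. That value is a limit of the assay and not a number, so compound 2 has no exact place on the scale. Compound 1 also gives a limit, > 50000 nM. The whole picture so far is the limit of > 50000 nM in this assay, at which 2 of the 2 values shown sit.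

Compound 3 `CCn1c(C(=O)NC(CC(=O)O)C(=O)OC)ccc1C(CC)(CC)c1ccc(OCCC(O)(CC)CC)c(C)c1` keeps the shared core of compound 2 and alters one side group: carboxymethyl in place of sec-butyl on a saturated chain carbon bound to an amide-type nitrogen and a carbonyl carbon. Put simply, carboxymethyl takes the place of sec-butyl.

Among the measured compounds shown here, one measured step bears on this change, and it is a step that the two limits leave unreadable from compound 1 to compound 2. It involves a different swap, on a carbonyl carbon, and it offers neither a size nor a direction to carry over. The expectation therefore rests on compound 2 and its limit of > 50000 nM, and no clear gain in this assay is expected. The estimated change is a number no higher from compound 2 to compound 3 (the limit leaves the size open). The assay may well report only a limit again. For compound 3 the expected value is 50000 nM, with an estimated range from 15000 nM to 100000 nM.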

Compound 3, half-maximal inhibitory concentration: 25200 nM
For compound 3 the middle estimate is 2.0-fold (0.30 log units) above the measured one; the measured number falls inside the stated range.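

Among the compounds shown here, compound 3 is the first compound here with an exact place on the scale: in this assay compound 3 gives 25200 nM. A change on this saturated chain carbon can now be followed by a number on one side. As far as these compounds go, putting carboxymethyl in place of sec-butyl gives an at least 1.9-fold lower number from compound 2 to compound 3 (0.29 log units; that floor lies within the scatter), and the larger change on the carbonyl carbon gives an at least 1.9-fold lower number from compound 1 to compound 3 (0.29 log units; that floor lies within the scatter); each of these is only a floor, so the real size of the step stays unknown, and what can be read of it does not clear the usual scatter. The other two values remain limits and not numbers: the limit of > 50000 nM in this assay, at which 2 of the 3 values shown sit.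

The step from compound 1 to compound 2 joins two limits and cannot be read, so the compounds shown do not tell whether the change on the carbonyl carbon matters on its own. They also leave open how the number would respond at the carboxymethyl place to an aminomethyl group, a hydroxymethyl group or a longer chain such as carboxyethyl.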